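A few compounds are considered here, and "the series" means these few. Any claim that something is new, unique, unknown or untested is made for them only; others in the source may bear on it.

Measured so far in a functional assay on XF498 cells (Homo sapiens) for cytotoxicity; a lower number here means that less compound is needed, a higher number that more compound is needed for the effect

compound 1 `CC(=O)C(O)C(O)C/C(C)=C\CC[C@H](C)/C=C/C=C(\C)CCCC1=CC(=O)OC1O` gives 11.5 ug/mL
compound 2 `C/C(=C\CCc1ccoc1)C[C@@H]1C=C(C/C=C/c2ccoc2)C(=O)O1` gives 11.8 ug/mL
compound 3 `COC1C=C(CCC/C(C)=C/C=C/[C@@H](C)CC/C=C(/C)C[C@H]2OC(=O)C(C)=C2O)C(=O)O1` gives > 30 ug/mL as a limit, not a number

Compound 3 stands at the limit of this assay and its > 30 ug/mL is a limit and not a number. Compound 1 and compound 2 lie within the usual scatter of each other.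

Compound 4 `CC1=C(O)[C@@H](C/C(C)=C\CC[C@H](C)/C=C/C=C(\C)CCCC2=CCN(CC(=O)O)C2=O)OC1=O` differs from compound 3 in one place, with a group of 10 heavy atoms (6 carbon, 1 nitrogen, 3 oxygen; one five-membered non-aromatic ring with 1 hetero atom) in place of a group of 8 heavy atoms (5 carbon, 3 oxygen; one five-membered non-aromatic ring with 1 hetero atom), on a saturated chain carbon, three bonds along the chain from a double-bonded chain carbon as the counted change, on a saturated chain carbon, three bonds along the chain from a double-bonded chain carbon.

Within the data shown here, no step between measured compounds gives a size for this change, so the expectation is loose. The expected at least 1.2-fold lower number from compound 3 to compound 4 (0.07 log units; that floor lies within the scatter) is small and, if it shows at all, points towards a lower number. Among the measured compounds shown here, the low end of the expected range rests on compound 1 at 11.5 ug/mL and compound 2 at 11.8 ug/mL as the only true numbers. A second limit reading is about as likely as a number. For compound 4 the estimate is 25 ug/mL with an expected range from 11 ug/mL to 45 ug/mL in this read-out.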

Compound 4, concentration for half-maximal effect: > 30 ug/mL
Compound 4 was reported as a limit; the forecaster's own chance of this, stated with the estimate: 50%; middle value at least 1.2-fold (0.07 log units) from the limit.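

In this assay, compound 3 and compound 4 are both reported only as limits, so no step can be read between them: the limit of > 30 ug/mL in this assay, at which 2 of the 4 values shown sit. The compounds shown leave open whether the group of 10 heavy atoms, in place of the group of 8 heavy atoms, shifts this read-out at all.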